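The compounds below may be only part of what the source reports. "The series", "measured", "known", "first", "only" and "open" are said of these compounds alone.

Measured so far in an ADME assay on MOLT-3 cells (Homo sapiens) for cytotoxicity, with a stated time of 7 days; a lower number here means that less compound is tolerated, a higher number that more compound is tolerated:
- compound 2, `CCCCCCCCSc1nc(N)nc2c1ncn2/C=C1/CC1(CO)CO`: > 20000 nM
- compound 1, `CC(C)CNc1nc(N)nc2c1ncn2/C=C1/CC1(CO)CO`: "not determined" (no result reported)

Compound 2 sits at a limit of this assay rather than at a number; of the two entries shown, it is the only one with any reading, and that reading is the limit (the limit of > 20000 nM in this assay, at which 1 of the 2 values shown sits). Among the compounds with values here, compound 1 has no result in this assay, so no step between measured compounds can be drawn.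

The next compound, compound 3, `C=CCOc1nc(N)nc2c1ncn2/C=C1/CC1(CO)CO`, is to be measured in this assay. It differs from compound 2 by allyloxy in place of octylsulfanyl on an aromatic carbon.

Because compound 2 stands at > 20000 nM, no direction or size of step can be read from the data. Compound 3 is expected to remain near or beyond the same limit, with the step of a number no higher from compound 2 to compound 3 (the limit leaves the size open) estimated as none beyond the scatter. Compound 3 is estimated at 20000 nM, with a range from 5000 nM to 60000 nM.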

Compound 3, half-maximal cytotoxic concentration: > 20000 nM
Compound 3: no number, only a limit; the forecaster's own chance of this, stated with the estimate: 70%; the middle value lies on the limit itself.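

No step can be read between compound 2 and compound 3 in this assay, as both readings are limits rather than numbers: the limit of > 20000 nM in this assay, at which 2 of the 3 values shown sit.

The compounds shown leave open whether allyloxy in place of octylsulfanyl alters tolerance, and at what concentration compound 2 or compound 3 reaches half-maximal cytotoxicity.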